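Swapping a Fluorinated Ring for a Methylated One

The compounds below may be only part of what the source reports. "The series", "measured", "known", "first", "only" and "open" are said of these compounds alone.

Among the compounds with values here, compound 2 `CC1=CCCC(C)(C)C1/C=C/C(=O)/C=C/c1ccccc1F` gives 4800 nM in a functional assay on PC-3 cells (Homo sapiens) for cytotoxicity, read by MTT assay, with a stated time of 72 h (on this read-out lower numbers stand for stronger inhibition and higher numbers for weaker inhibition), the lowest of the two numbers known here, while compound 1 `CC1=CCCC(C)(C)C1/C=C/C(=O)/C=C/c1ccccc1C(F)(F)F` gives 19000 nM. Within the data shown here, the only measured step, a 4.0-fold lower number from compound 1 to compound 2 (0.60 log units; beyond the scatter), changes a group on the aromatic ring but keeps a fluorine in place; compound 3 `CC1=CCCC(C)(C)C1/C=C/C(=O)/C=C/c1cccc(C)c1` removes the fluorine altogether, with 3-methylphenyl in place of 2-fluorophenyl on a double-bonded chain carbon bound to a double-bonded chain carbon. Among the measured compounds shown here, no measured step bears directly on this change, so in this assay no step beyond the scatter is expected, though with wide uncertainty. Compound 3 is estimated at 5000 nM, between 1500 nM and 16000 nM. The expected step is a 1.0-fold higher number from compound 2 to compound 3 (0.02 log units; within the scatter).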

Compound 3, half-maximal inhibitory concentration: 5900 nM
For compound 3 the middle estimate is 1.2-fold (0.07 log units) below the measured one; low and high end bracket the measured number.
By their numbers in this assay, from the lowest: compounds 2 and 3 (each within the scatter of the next); then compound 1.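

Read in this assay the swap of 2-fluorophenyl for 3-methylphenyl gives a 1.2-fold higher number from compound 2 to compound 3 (0.09 log units; within the scatter) so this place on the chain accepts a ring without fluorine, with no difference beyond the scatter. Because the fluorine goes and the methyl arrives in one step, the two changes cannot be told apart here. Nothing measured here explains the result.

Going by these compounds, whether an amine or a carboxylic acid on this ring would give a similar number remains open. So does the effect of a plain, unsubstituted phenyl ring at this place.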